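A few compounds are considered here, and "the series" means these few. Any claim that something is new, unique, unknown or untested is made for them only; others in the source may bear on it.

Compound 1 `COC(=O)[C@]1(Cc2ccc(O)c(CC=C(C)C)c2)OC(=O)C(O)=C1c1ccc(O)c(CC=C(C)C)c1` carries two open arms on the shared core; in a functional assay on HCC1806 cells (Homo sapiens) for antiproliferative activity, read by CCK-8 assay, with a stated time of 24 h (a higher number here means a weaker inhibitor, a lower number a stronger inhibitor), compound 1 gives 17600 nM. Compound 2 `COC(=O)[C@]1(Cc2ccc3c(c2)C[C@H](O)C(C)(C)O3)OC(=O)C(O)=C1c1ccc(O)cc1` closes one arm into a fused six-membered non-aromatic ring bearing a hydroxy on a saturated ring carbon. In this assay compound 2 reaches only the limit of the assay, > 20000 nM, and no number is obtained. Compound 3 `COC(=O)[C@]1(Cc2ccc3c(c2)C[C@H](C(C)(C)O)O3)OC(=O)C(O)=C1c1ccc(O)cc1` carries the same fused ring with the hydroxy placed differently. In this assay compound 3 likewise reaches only the assay limit, > 20000 nM. Going by the values given here, compound 2 thus stands at the weak end of what is known: the limit of > 20000 nM in this assay, at which 2 of the 3 values shown sit, and the single numerical value, that of compound 1, lies close to that limit. Among the compounds with values here, no pair of measured compounds differing in one place exists in this set, so no measured step is available.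

Compound 4 `COC(=O)[C@]1(Cc2ccc3c(c2)CCC(C)(C)O3)OC(=O)C(O)=C1c1ccc(O)cc1` differs from compound 2 by hydrogen in place of hydroxy on a saturated ring carbon. Within the data shown here, no measured pair tests this change. Compound 2 gives only the assay limit, > 20000 nM. With compound 1 sitting at 17600 nM, the step from compound 2 to compound 4 is expected to be an at least 1.1-fold lower number from compound 2 to compound 4 (0.04 log units; that floor lies within the scatter), not beyond the scatter in either direction. Compound 4 is estimated at 18000 nM in this assay, between 6000 nM and 50000 nM, with a fair chance that again only a limit is reported.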

Compound 4, half-maximal inhibitory concentration: > 20000 nM
Compound 4 was reported as a limit; the forecaster's own chance of this, stated with the estimate: 60%; at least 1.1-fold (0.04 log units) between middle value and limit.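

In this assay compound 4 gives > 20000 nM, a limit and not a number. Going by these compounds alone, with compound 2 also at a limit, no step between compound 2 and compound 4 can be read. The compounds shown leave open whether hydrogen in place of hydroxy on a saturated ring carbon changes antiproliferative activity, and how far past the limit either compound lies.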